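Lactone to furanylcarbinol on a labdane-type side chain

The source may report more compounds than this note shows. Statements on the series, on what has been measured and on what is new or still open speak of the compounds shown alone.

Of the compounds shown here, three with a shared core have been measured in a functional assay on B16 cells (Mus musculus) for cytotoxicity; on this read-out lower numbers stand for stronger inhibition and higher numbers for weaker inhibition. Compound 1 `C=C1CC[C@H]2C(C)(C)CCC[C@]2(C)[C@H]1C/C=C1/CCOC1=O` gives 7.5 ug/mL, the lowest of the three numbers. Compound 2 `CC(=O)O[C@]1(C)CC[C@H]2C(C)(C)CCC[C@]2(C)[C@H]1C/C=C1/CCOC1=O` gives 11.3 ug/mL, which lies within the scatter of the number for compound 1. Compound 3 `C=C1CC[C@H]2C(C)(C)CCC[C@]2(C)[C@H]1/C=C/c1ccoc1` gives 18.8 ug/mL, a gap from compound 1 that lies beyond the scatter. No pair among these three differs in only one place, so no single step can be read off.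

Compound 4 `C=C1CC[C@H]2C(C)(C)CCC[C@]2(C)[C@H]1CC(O)c1ccoc1` is not yet measured. It is built from the same atoms as compound 1, joined differently: a group of 7 heavy atoms (5 carbon, 2 oxygen; one five-membered aromatic ring with 1 hetero atom) in place of a group of 7 heavy atoms (5 carbon, 2 oxygen; one five-membered non-aromatic ring with 1 hetero atom), on a saturated chain carbon bound to a saturated ring carbon. The change replaces the non-aromatic ring by the aromatic ring that compound 3 also carries, and compound 3 sits above compound 1 in this assay. On that basis a step toward a higher number is expected, of about the size a 1.7-fold higher number from compound 1 to compound 4 (0.24 log units; within the scatter), possibly beyond the scatter. Compound 4 is estimated to give 13 ug/mL, with a range from 5 ug/mL to 35 ug/mL.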

Compound 4, half-maximal inhibitory concentration: 47.2 ug/mL
Compound 4: the middle estimate sits 3.6-fold (0.56 log units) below what was measured; the whole stated range lies below it.
By their numbers in this assay, from the lowest: compounds 1, 2 and 3 (each within the scatter of the next, the first and the last beyond it); then compound 4.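

In this assay, within the data shown here, the step from the lactone-bearing group to (furan-3-yl)(hydroxy)methyl, on a saturated chain carbon bound to a saturated ring carbon, is the first single change that can be read (a 6.3-fold higher number from compound 1 to compound 4 (0.80 log units; beyond the scatter)). It shows that this place is not indifferent to how these atoms are joined: two groups of the same size and composition give numbers that lie beyond the scatter of each other. No measurement at hand bears on why the step arises. Going by these compounds, whether it follows the furan ring, the hydroxy group or the loss of the lactone stays open, as these changes enter together. A carbonyl or an amine in place of that hydroxy group, with the furan ring kept, is not among the compounds shown.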